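Carrying a Phenol Capping Step to a Second Core

This account rests on a few compounds, and the source may have more. Where it says the series, first, only, none or still open, it means among the compounds named here.

Compound 1 `COc1cc(CNC(=O)/C=C/c2ccccc2OCc2nc(C)c(C)nc2C)ccc1O` and compound 2 `COc1cc(CNC(=O)/C=C/c2ccccc2OCc2nc(C)c(C)nc2C)ccc1OCc1nc(C)c(C)nc1C` share one core, while compound 3 `COc1cc(CNC(=O)/C=C/c2cccc(OC)c2OC)ccc1O` and compound 4 `COc1cc(CNC(=O)/C=C/c2cccc(OC)c2OC)ccc1OCc1nc(C)c(C)nc1C` share another; the difference between the two cores is not broken down here. In a functional assay on SH-SY5Y cells (Homo sapiens) for cytotoxicity, read by MTT assay, with stated times of 24 h and 4 h (a higher number here means that more compound is needed for the effect, a lower number that less compound is needed), compound 1 gives 12000 nM, compound 2 gives 6280 nM and compound 3 gives 5490 nM. The change from compound 1 to compound 2 is (3,5,6-trimethylpyrazin-2-yl)methyl in place of hydrogen on an oxygen on an aromatic ring, and it made a 1.9-fold lower number from compound 1 to compound 2 (0.28 log units; within the scatter). The same change, ((3,5,6-trimethylpyrazin-2-yl)methyl in place of hydrogen on an oxygen on an aromatic ring), carries compound 3 to compound 4. The expectation for compound 4 rests on compound 1 and compound 2, whose step a 1.9-fold lower number from compound 1 to compound 2 (0.28 log units; within the scatter) stayed within the scatter, so only a modest move is expected. The estimated step to compound 4 is a 1.6-fold lower number from compound 3 to compound 4 (0.20 log units; within the scatter). Compound 4 is therefore expected at about 3500 nM in this assay, with a likely range from 1500 nM to 8000 nM.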

Compound 4, half-maximal effective concentration: 7150 nM
Compound 4: the middle estimate sits 2.0-fold (0.31 log units) below what was measured; measured number inside the range.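

In this assay, the change from hydroxy to (3,5,6-trimethylpyrazin-2-yl)methoxy gave a 1.3-fold higher number from compound 3 to compound 4 (0.11 log units; within the scatter). Set beside the earlier step, the two readings do not separate: the same change on two cores in this assay, a 1.9-fold lower number (0.28 log units; within the scatter) from compound 1 to compound 2 and a 1.3-fold higher number (0.11 log units; within the scatter) from compound 3 to compound 4, 2.5-fold (0.40 log units) apart, within the scatter of two such steps. On both cores the change thus stays within the scatter, but these two pairs show neither a real effect of the change nor any dependence on the core, and two pairs in one assay cannot support a general rule.

The compounds shown leave open whether another group on that oxygen, such as a plain methyl, a longer chain or a chain ending in an amine or a carboxylic acid, would move the number beyond the scatter. They also leave open how the change reads on any further core.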